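The source may report more compounds than this note shows. Statements on the series, on what has been measured and on what is new or still open speak of the compounds shown alone.

Measured so far:
compound 1 `CC(=O)OC/C(=C\c1ccccc1Br)C(=O)c1ccccc1` gives 14000 nM
compound 2 `CC(=O)OC/C(=C/c1ccccc1Cl)C(=O)c1ccccc1` gives 14000 nM

In a functional assay on SW1573 cells (Homo sapiens) for inhibition, read by sulforhodamine B assay, with a stated time of 48 h (a lower number here means a stronger inhibitor of growth, a higher number a weaker inhibitor of growth), compound 2 stands level with compound 1 at the digits shown, the two values falling within the scatter of each other. Compound 3 `CC(=O)OC/C(=C/c1ccccc1Br)C(=O)c1ccccc1` is not yet measured; it differs from compound 2 by bromo in place of chloro on an aromatic carbon. Within the data shown here, no measured pair shows this step, so the account expects no shift beyond the scatter, in either direction, with the step from no change at the digits printed from compound 2 to compound 3 (within the scatter) estimated near zero. Compound 3 is accordingly estimated at 14000 nM in this assay, within a range from 7000 nM to 28000 nM.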

Compound 3, concentration for 50% growth inhibition: 21000 nM
The estimate for compound 3 lay 1.5-fold (0.18 log units) below the measured number, within the range that was stated.
By their numbers in this assay, from the lowest: compounds 1, 2 and 3 (each within the scatter of the next).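

In this assay, bromo in place of chloro on an aromatic carbon ortho to a large group gives a 1.5-fold higher number from compound 2 to compound 3 (0.18 log units; within the scatter), so the two halogens cannot be told apart at this position. The configuration of the double bond can now also be read on its own, and it gives a 1.5-fold higher number from compound 1 to compound 3 (0.18 log units; within the scatter), a clean comparison of the two drawn forms: the fact that compounds 1 and 3 differ only in the configuration as drawn.

The compounds shown leave open whether an amine or a carboxylic acid in place of the halogen would move the number in this assay beyond the scatter. They also leave open what a longer chain in place of the acetyl group would do.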